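This account rests on a few compounds, and the source may have more. Where it says the series, first, only, none or still open, it means among the compounds named here.

Measured compounds in an in vitro functional assay on cells for agonist activity at Bombesin receptor subtype-3 (Homo sapiens), read by luminescence and calcium flux; a lower number here means that less compound is needed, a higher number that more compound is needed for the effect:
compound 1 `O=C(O)c1ccccc1-c1ccc(CCc2ncc(CC3CCCCCC3)[nH]2)cc1`: 88 nM
compound 2 `CC(C)(C)CCc1cnc(CCc2ccc(-c3ccccc3C(=O)O)cc2)[nH]1`: 39 nM
compound 3 `Cc1ccc(Cc2cnc(CCc3ccc(-c4ccccc4C(=O)O)cc3)[nH]2)cc1`: 2660 nM

Compound 3 holds the highest number of the three. The two steps leading to it are large: a 30-fold higher number from compound 1 to compound 3 (1.48 log units; beyond the scatter) and a 68-fold higher number from compound 2 to compound 3 (1.83 log units; beyond the scatter), both beyond the scatter, so within this set a 4-methylphenyl group on the saturated chain carbon bound to an aromatic carbon is clearly the least favourable of the three substituents tried. Between the two saturated groups the difference is modest, a 2.3-fold lower number from compound 1 to compound 2 (0.35 log units; beyond the scatter).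

Compound 4 `COc1cccc(Cc2cnc(CCc3ccc(-c4ccccc4C(=O)O)cc3)[nH]2)c1` keeps the shared core and changes only the group at that position: 3-methoxyphenyl in place of 4-methylphenyl on a saturated chain carbon bound to an aromatic carbon. The same difference, cut one bond further out, reads 4-methylbenzyl to 3-methoxybenzyl. Within the data shown here, no measured step compares one aromatic group with another at this position; the steps on record all set an aromatic group against a saturated one. They therefore give no direction for this change, and a step within the scatter is the default expectation, with wide uncertainty in either direction.

Compound 4 is accordingly expected to give about 2500 nM, within 700 nM to 9000 nM, which would mean a step of a 1.1-fold lower number from compound 3 to compound 4 (0.03 log units; within the scatter) in this assay.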

Compound 4, half-maximal effective concentration: 4120 nM
Estimate against measurement, compound 4: 1.6-fold (0.22 log units) below; measured number inside the range.
By their numbers in this assay, from the lowest: compound 2; then compound 1; then compounds 3 and 4 (each within the scatter of the next).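

In this assay, among these compounds, the first comparison of one aromatic group with another on the saturated chain carbon bound to an aromatic carbon gives a 1.5-fold higher number from compound 3 to compound 4 (0.19 log units; within the scatter) and so does not separate 3-methoxyphenyl from 4-methylphenyl, although the entering group brings an oxygen and a hydrogen-bond acceptor. The large gap to the saturated groups now rests on a second aromatic group, with a 110-fold higher number from compound 2 to compound 4 (2.02 log units; beyond the scatter) and a 47-fold higher number from compound 1 to compound 4 (1.67 log units; beyond the scatter) as the steps, so across these four compounds both aromatic groups give far higher numbers than neopentyl and cycloheptyl, and no compound shown goes against this. Nothing on hand explains this gap or the absence of a clear difference between the two aromatic groups.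

Still open, going by these compounds, is whether any aromatic group at this position can approach the numbers of the saturated groups, for instance a pyridine ring or a phenyl ring carrying an amine or a hydroxyl. Also open, on these data alone, is how far the saturated side extends, for instance to a cyclopentyl group or a longer unbranched chain.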